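Same swap of dichlorophenyl pattern on a second core

The source may report more compounds than this note shows. Statements on the series, on what has been measured and on what is new or still open speak of the compounds shown alone.

Measured compounds in an ADME assay on MT4 cells (Homo sapiens) for cytotoxicity, read by MTT assay; on this read-out higher numbers stand for lower toxicity in this test and lower numbers for higher toxicity in this test:
Compound 1 `O=C1c2ccccc2C(=O)N1CCOC(=S)N(C(=O)c1cccc(Cl)c1Cl)c1ccc(Cl)cc1` gives 54000 nM.
Compound 2 `O=C1c2ccccc2C(=O)N1CCOC(=S)N(C(=O)c1ccc(Cl)cc1Cl)c1ccc(Cl)cc1` gives 18000 nM.
Compound 3 `Cc1ccc(N(C(=O)c2cccc(Cl)c2Cl)C(=S)OCCN2C(=O)c3ccccc3C2=O)cc1` gives 35000 nM.

Compound 4 `Cc1ccc(N(C(=O)c2ccc(Cl)cc2Cl)C(=S)OCCN2C(=O)c3ccccc3C2=O)cc1` has not yet been measured in this assay.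

Compounds 1 and 2 share one core and differ in this way: 2,4-dichlorophenyl in place of 2,3-dichlorophenyl on a carbonyl carbon. That change produced a 3.0-fold lower number from compound 1 to compound 2 (0.48 log units; beyond the scatter). Compound 3 carries a different core, and the difference between it and compound 1 is this: methyl in place of chloro on an aromatic carbon. Measured side by side, that core change gave a 1.5-fold lower number from compound 1 to compound 3 (0.19 log units; within the scatter). Compounds 2 and 3 are not compared as a step here; their two values simply stand as given.

Compound 4 differs from compound 3 in exactly this way: 2,4-dichlorophenyl in place of 2,3-dichlorophenyl on a carbonyl carbon. The place of the change reads the same, word for word, as in the pair of compounds 1 and 2, so this is the same change, made once more on the second core.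

Among the measured compounds shown here, the expectation for compound 4 rests on the one measured example: because a 3.0-fold lower number from compound 1 to compound 2 (0.48 log units; beyond the scatter) was observed on the first core, a step of similar size and direction is estimated on the second core, namely a 2.9-fold lower number from compound 3 to compound 4 (0.46 log units; beyond the scatter). On that basis compound 4 is expected to give about 12000 nM in this assay, with a range from 6000 nM to 25000 nM, since a single precedent leaves the size of the step uncertain.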

Compound 4, half-maximal cytotoxic concentration: 49000 nM
The estimate for compound 4 lay 4.1-fold (0.61 log units) below the measured number; measured number above the stated range.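

In this assay, putting 2,4-dichlorophenyl in place of 2,3-dichlorophenyl on a carbonyl carbon gave a 1.4-fold higher number from compound 3 to compound 4 (0.15 log units; within the scatter), so the clear step seen on the core of compound 1 did not carry over to the core of compound 3: the same change on two cores in this assay, a 3.0-fold lower number (0.48 log units; beyond the scatter) from compound 1 to compound 2 and a 1.4-fold higher number (0.15 log units; within the scatter) from compound 3 to compound 4, 4.2-fold (0.62 log units) apart, beyond the scatter of two such steps. Read the other way around the same four compounds, methyl in place of chloro on an aromatic carbon gave a 2.7-fold higher number from compound 2 to compound 4 (0.43 log units; beyond the scatter), and this step too depends on what stands at the other site: the same change on two cores in this assay, a 1.5-fold lower number (0.19 log units; within the scatter) from compound 1 to compound 3 and a 2.7-fold higher number (0.43 log units; beyond the scatter) from compound 2 to compound 4, 4.2-fold (0.62 log units) apart, beyond the scatter of two such steps. These two gaps are one finding seen from two sides, showing that in this set of four the two changes do not act independently, so a step measured on one core is a poor guide to the other; it does not show why this happens, or whether it holds for any compound outside the set.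

As far as these compounds go, what remains open is whether the same dependence would appear with other groups in place of chloro or methyl on the aromatic carbon, such as fluoro or methoxy. From the compounds shown here alone, it is also open how a plain phenyl on the carbonyl carbon, or a longer chain leading to the phthalimide-bearing end of the molecule, would behave on these two cores.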